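Swapping ethylamino for dimethylamino on a weak inhibitor

The compounds below may be only part of what the source reports. "The series", "measured", "known", "first", "only" and "open" are said of these compounds alone.

In a functional assay with Mus musculus as the target (a higher number here means a weaker inhibitor, a lower number a stronger inhibitor), compound 1 `N[C@@H]1CCCc2onc(O)c21` gives 681000 nM. Compound 2 `CCNC1CCCc2onc(O)c21` gives 391000 nM, and these two numbers lie within the scatter of each other, so neither compound stands apart from the other. Compound 3 `CN(C)C1CCCc2onc(O)c21` has not yet been measured. It carries dimethylamino in place of ethylamino on a saturated ring carbon. Going by the values given here, the two compounds have the same atoms, joined differently, and no measured pair shows a change of this kind. The expectation therefore starts from compound 2 at 391000 nM, and no step beyond the scatter is expected in this assay, in either direction. The estimated change is a 1.0-fold higher number from compound 2 to compound 3 (0.01 log units; within the scatter). Compound 3 is expected at 400000 nM, with an estimated range from 150000 nM to 1000000 nM.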

Compound 3, half-maximal inhibitory concentration: > 1000000 nM
Compound 3 ended at the assay's limit; the forecaster's own chance of this, stated with the estimate: 15%; at least 2.5-fold (0.39 log units) between middle value and limit.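

In this assay compound 3 gives > 1000000 nM, which is a limit of the assay and not a number. Going by these compounds alone, the result is an at least 2.5-fold higher number from compound 2 to compound 3 (0.40 log units; beyond the scatter), the first step at this saturated ring carbon to lie beyond the scatter, and it comes from a change that keeps the same heavy atoms in the group but replaces ethylamino, which has a hydrogen-bond donor, with dimethylamino, which has none. As far as these compounds go, the true size of the step stays unknown because the value of compound 3 is a limit: the limit of > 1000000 nM in this assay, at which 1 of the 3 values shown sits.

The compounds shown leave open whether the lost hydrogen-bond donor or the new arrangement of the same atoms accounts for the step. Methylamino or propylamino on the same saturated ring carbon would help to tell these two readings apart.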